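The source may hold more compounds than are shown below. What is called first, only, known or untested is meant among the compounds shown, and "the series" means these compounds.

In a functional assay on A549 cells (Homo sapiens) for antiproliferative activity, read by MTT assay, with a stated time of 24 h (a lower number here means a stronger inhibitor, a higher number a weaker inhibitor), compound 1 `Cc1ccc(-c2nn(-c3ccccc3)cc2-c2nc3ccccc3n2S(=O)(=O)c2cc(C)ccc2C)cc1` gives 270 nM, compound 2 `O=S(=O)(c1ccccc1)n1c(-c2cn(-c3ccccc3)nc2-c2ccc(C(F)(F)F)cc2)nc2ccccc21` gives 480 nM and compound 3 `Cc1ccc(C)c(S(=O)(=O)n2c(-c3cn(-c4ccccc4)nc3-c3ccc(C(F)(F)F)cc3)nc3ccccc32)c1` gives 150 nM. Trifluoromethyl in place of methyl gives a 1.8-fold lower number from compound 1 to compound 3 (0.26 log units; within the scatter), so that pair cannot be ranked. Compound 3 therefore stands level with compound 1 and clearly better than compound 2. Compound 4 `O=S(=O)(c1ccc(Br)cc1)n1c(-c2cn(-c3ccccc3)nc2-c2ccc(C(F)(F)F)cc2)nc2ccccc21` alters the group on the sulfonyl sulfur: 4-bromophenyl in place of 2,5-dimethylphenyl on a sulfonyl sulfur. Among the compounds with values here, the only measured change at that place, 2,5-dimethylphenyl in place of phenyl, gave a 3.2-fold lower number from compound 2 to compound 3 (0.51 log units; beyond the scatter), and no measured compound carries bromine. Part of that modest gain is expected to be lost, so the expected change is a 1.9-fold higher number from compound 3 to compound 4 (0.27 log units; within the scatter), towards a higher number. For compound 4 the estimated value is 280 nM, with an expected range of 110 nM to 700 nM.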

Compound 4, half-maximal inhibitory concentration: 1690 nM
Beside the measured number, compound 4's estimate is 6.0-fold (0.78 log units) below it, outside the stated range (above it).
By their numbers in this assay, from the lowest: compounds 3, 1 and 2 (each within the scatter of the next, the first and the last beyond it); then compound 4.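

In this assay, within the data shown here, the group on the sulfonyl sulfur can shift the number much further than the earlier compounds showed: 4-bromophenyl in place of 2,5-dimethylphenyl gives a large loss (an 11-fold higher number from compound 3 to compound 4 (1.05 log units; beyond the scatter)). Bromo in place of hydrogen on an aromatic carbon also raises the number (a 3.5-fold higher number from compound 2 to compound 4 (0.55 log units; beyond the scatter)), so changes from plain phenyl at this place can go either way. Nothing here explains these shifts. From the compounds shown here alone, it remains open how an amine or a carboxylic acid in place of the bromine would behave, and whether a simple alkyl chain on the sulfonyl sulfur would be tolerated.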